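Compound 3 and the step to compound 4

The compounds below may be only part of what the source reports. "The series", "measured", "known", "first", "only" and "open" are said of these compounds alone.

compound 1 `CCOC(=O)CN(C)C(=O)c1ccc(C(CC)(CC)c2ccc(OCCC(O)(CC)CC)c(C)c2)n1CC` gives 7140 nM
compound 2 `CCC(C)C(NC(=O)c1ccc(C(CC)(CC)c2ccc(OCCC(O)(CC)CC)c(C)c2)n1CC)C(=O)O` gives 13800 nM
compound 3 `CCn1c(C(=O)N(C)CC(=O)O)ccc1C(CC)(CC)c1ccc(OCCC(O)(CC)CC)c(C)c1` gives 2250 nM
compound 4 `CCn1c(C(=O)NC(C)C(=O)O)ccc1C(CC)(CC)c1ccc(OCCC(O)(CC)CC)c(C)c1` is still unmeasured

In a functional assay on PC-3 cells (Homo sapiens) for antiproliferative activity, read by MTT assay, with a stated time of 48 h (a lower number here means a stronger inhibitor, a higher number a weaker inhibitor), compound 3 stands lowest of the three numbers, beyond the scatter from both others. Compound 4 differs by (1-carboxyethyl)amino in place of (carboxymethyl)(methyl)amino on a carbonyl carbon in one place: (1-carboxyethyl)amino in place of (carboxymethyl)(methyl)amino on a carbonyl carbon. The closest evidence is a 6.1-fold lower number from compound 2 to compound 3 (0.79 log units; beyond the scatter) at that same carbonyl carbon. The group removed there, (1-carboxy-2-methylbutyl)amino, most resembles the entering group. By contrast, a 3.2-fold lower number from compound 1 to compound 3 (0.50 log units; beyond the scatter) concerns a different change and bears only loosely. A higher number is expected, but a smaller rise than the one at that carbonyl carbon. The estimate is a 2.2-fold higher number from compound 3 to compound 4 (0.35 log units; beyond the scatter) as an expectation only. Compound 4 is expected at 5000 nM in this assay with 1800 nM to 14000 nM as the estimated range.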

Compound 4, half-maximal inhibitory concentration: 11700 nM
For compound 4 the middle estimate is 2.3-fold (0.37 log units) below the measured one; measured number inside the range.
By their numbers in this assay, from the lowest: compound 3; then compounds 1, 4 and 2 (each within the scatter of the next).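

In this assay the same atoms joined differently at this carbonyl carbon do not give the same result (a 5.2-fold higher number from compound 3 to compound 4 (0.72 log units; beyond the scatter)), so the lead of compound 3 does not carry over to (1-carboxyethyl)amino. Methyl in place of sec-butyl on the chain carbon stays within the scatter (a 1.2-fold lower number from compound 2 to compound 4 (0.07 log units; within the scatter)), and so does the step from the ethyl ester (a 1.6-fold higher number from compound 1 to compound 4 (0.21 log units; within the scatter)). Moving the methyl therefore matters here more than the size of that chain did.

Where (carboxymethyl)amino, with neither methyl, would fall remains open, so the amide hydrogen and the chain methyl cannot be told apart. Nothing measured here explains these differences.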